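The compounds below may be only part of what the source reports. "The series", "measured", "known", "first", "only" and "open" are said of these compounds alone.

Measured compounds in a functional assay (strain AB) with Danio rerio as the target, read by microscopy, with a stated time of 1 h; on this read-out lower numbers stand for an effect already at smaller amounts and higher numbers for an effect only at larger amounts of compound:
compound 1 `CC(C)(C)CN1CCc2c(sc(NC(=O)Nc3ccc(Cl)cc3)c2C(N)=O)C1` gives 5560 nM.
Compound 2 `CCN1CCc2c(sc(NC(=O)Nc3ccc(Cl)cc3)c2C(=O)c2nc(C)no2)C1` gives > 25000 nM, which is a limit of the assay rather than a number.

Compound 1 therefore holds the only number shown; the other value sits at the limit of > 25000 nM in this assay, at which 1 of the 2 values shown sits. Among the measured compounds shown here, compound 1 and compound 2 differ in more than one place, so no single-change step between measured compounds exists, and the two values only show that compound 1 gives a number where compound 2 gives a limit.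

Compound 3 `CC(C)(C)OC(=O)CCCCN1CCc2c(sc(NC(=O)Nc3ccc(Cl)cc3)c2C(N)=O)C1` differs from compound 1 in one place: 3-(tert-butoxycarbonyl)propyl in place of tert-butyl on a saturated chain carbon bound to an amine nitrogen in a ring. For the measured compounds named here, no measured step tells how such a change acts in this assay, so the expectation rests on compound 1 alone.

Compound 3 is expected to sit near compound 1, with a step of a 1.6-fold higher number from compound 1 to compound 3 (0.21 log units; within the scatter) that leans toward an effect only at somewhat larger amounts, barely beyond the scatter. Compound 3 is estimated at 9000 nM, within a range from 2500 nM to 25000 nM.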

Compound 3, half-maximal effective concentration: 710 nM
For compound 3 the middle estimate is 13-fold (1.10 log units) above the measured one; the whole stated range lies above it.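

Putting 3-(tert-butoxycarbonyl)propyl in place of tert-butyl on a saturated chain carbon bound to an amine nitrogen in a ring gives a 7.8-fold lower number from compound 1 to compound 3 (0.89 log units; beyond the scatter) in this assay, so the effect now appears at smaller amounts. This place therefore tolerates a far bigger group, with 10 heavy atoms entering where 4 leave, and the number moves beyond the scatter in the favourable direction. Nothing shown here accounts for why this change lowers the number.

Among the compounds shown here, with only this one change at this place, the step cannot yet be divided among the longer chain, the ester and its tert-butyl end. A carboxylic acid at the end of the chain, or a plain alkyl chain of similar length with no ester, would help to separate these parts.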